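This account rests on a few compounds, and the source may have more. Where it says the series, first, only, none or still open, it means among the compounds named here.

Measured so far:
- compound 1, `Cn1c(Cc2nn(C)c(=O)c3ccccc23)nnc1SCCCCCC(=O)Nc1ccc(Cl)cc1Cl`: 4100 nM
- compound 2, `CCCOc1ccc(NC(=O)CCCCCCCSc2nnc(Cc3nn(C)c(=O)c4ccccc34)n2C)cc1`: 1600 nM
- compound 3, `CC(C)Oc1ccc(NC(=O)CCCCCCCSc2nnc(Cc3nn(C)c(=O)c4ccccc34)n2C)cc1`: 1100 nM

In an assay on isolated protein (Mus musculus) for inhibition of IL15-IL15 receptor (Homo sapiens), read by resazurin assay, with stated times of 30 min and 2.5 days (a lower number here means a stronger inhibitor, a higher number a weaker inhibitor), compound 3 gives the lowest of the three numbers. Its nearest neighbour is compound 2, and the step of a 1.5-fold lower number from compound 2 to compound 3 (0.16 log units; within the scatter) stays within the usual scatter, so these two cannot be told apart. Compound 1 stands further off; the gap between compound 1 and compound 3 is beyond the scatter, but compound 1 differs from compound 3 in more than one place, so no single change can be read from it.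

Compound 4, `Cn1c(Cc2nn(C)c(=O)c3ccccc23)nnc1SCCCCCCCC(=O)Nc1ccc(Cl)cc1`, has not been measured. It differs from compound 3 in one place: chloro in place of isopropoxy on an aromatic carbon. Within the data shown here, none of the measured steps exchanges an alkoxy group for a chloro group; the only single step recorded, from compound 2 to compound 3, swaps one alkoxy group for another and lies within the scatter. Compound 1, which carries chloro groups on the same ring but also a different chain, sits at a higher number than compound 3. On this thin basis compound 4 is expected to land somewhat above compound 3, by a step of a 1.8-fold higher number from compound 3 to compound 4 (0.26 log units; within the scatter), though with wide uncertainty. The estimate for compound 4 in this assay is 2000 nM, with a range from 800 nM to 6000 nM.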

Compound 4, half-maximal inhibitory concentration: 800 nM
Compound 4: middle estimate off by 2.5-fold (0.40 log units), on the high side; the measured number falls inside the stated range.
By their numbers in this assay, from the lowest: compounds 4, 3 and 2 (each within the scatter of the next); then compound 1.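

At this place on the ring, para to a large group, a lone chloro can stand in for either alkoxy group with no readable difference in this assay: the steps, a 1.4-fold lower number from compound 3 to compound 4 (0.14 log units; within the scatter) and a 2.0-fold lower number from compound 2 to compound 4 (0.30 log units; within the scatter), both stay inside the usual scatter. The one clear gap is a 5.1-fold lower number from compound 1 to compound 4 (0.71 log units; beyond the scatter), but the length of the chain and the number of chloro groups on the ring change together in that step, so neither can be credited on its own. Nothing measured here explains why these groups read alike.

As far as these compounds go, whether the gap from compound 1 belongs to the chain or to the extra chloro stays open. So does how a group of another kind at this ring position, such as an amine, a carboxylic acid or a trifluoromethyl, would read in this assay.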